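This account rests on a few compounds, and the source may have more. Where it says the series, first, only, none or still open, it means among the compounds named here.

Among the compounds with values here, in a functional assay on HT-29 cells (Homo sapiens) for inhibition, read by MTT assay, with a stated time of 2 days (a higher number here means a weaker inhibitor, a lower number a stronger inhibitor), compound 1 (`Nc1cccc(/C=C/c2ccc(O)cc2)c1`) gives 51 ug/mL and has only one measured neighbour for comparison. Compound 2 (`COc1cccc(/C=C/c2ccc(O)cc2)c1`) gives 26 ug/mL in this assay, so the two values lie within the scatter of each other and neither can be ranked above the other. Compound 3 (`COc1ccc(/C=C/c2cccc(N)c2)cc1`) has not yet been measured. It keeps the amino group of compound 1, and the change is a single one (methyl in place of hydrogen on an oxygen on an aromatic ring), which also reads as hydroxy to methoxy. Within the data shown here, the one measured step that bears on this is methoxy in place of amino on an aromatic carbon, a 2.0-fold lower number from compound 1 to compound 2 (0.29 log units; within the scatter) in size. Among the measured compounds shown here, that step brings in a methoxy by replacing the amino group, not the hydroxy, so it is only indirect evidence, and no measured pair shows the hydroxy to methoxy change itself. No shift beyond the scatter is therefore expected in this assay. The expected step is a 1.3-fold lower number from compound 1 to compound 3 (0.13 log units; within the scatter) and should stay inside the scatter. For compound 3 the estimated value 38 ug/mL comes with a range from 15 ug/mL to 90 ug/mL in this estimate.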

Compound 3, half-maximal inhibitory concentration: 16.3 ug/mL
Compound 3: middle estimate off by 2.3-fold (0.37 log units), on the high side; the measured number falls inside the stated range.
By their numbers in this assay, from the lowest: compounds 3, 2 and 1 (each within the scatter of the next, the first and the last beyond it).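

Methyl in place of hydrogen on an oxygen on an aromatic ring gives a 3.1-fold lower number from compound 1 to compound 3 (0.50 log units; beyond the scatter) in this assay, which makes this modest change the first step shown in the series to pass beyond the scatter. Compound 1's hydroxy is thus not required for inhibition at this level: with the amino group kept, the methoxy at this position goes with a lower number, whereas the change at the amino position, a 2.0-fold lower number from compound 1 to compound 2 (0.29 log units; within the scatter), could not be told from the scatter. Nothing available accounts for the shift, so the result stands as an observation without an explanation.

With only hydrogen and methyl shown on this oxygen, it remains open whether a longer chain such as ethyl or propyl, or a benzyl or acetyl group, would extend the step, hold it or reverse it. Going by these compounds, it is equally open whether the step depends on the amino group of the shared core, and whether it would carry over to a compound with a dimethylamino or acetamido group in its place.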